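Salicylanilide-type amides: K562 cytotoxicity, methyl on the chain

A few compounds are considered here, and "the series" means these few. Any claim that something is new, unique, unknown or untested is made for them only; others in the source may bear on it.

Measured compounds:
compound 1 `C[C@@H](NC(=O)c1cc(Cl)ccc1O)C(=O)Nc1ccc(Cl)cc1`: > 20000 nM
compound 2 `O=C(CNC(=O)c1cc(Cl)ccc1O)Nc1cccc(Cl)c1`: > 10000 nM
compound 3 `C[C@H](NC(=O)c1ccc(Cl)cc1O)C(=O)Nc1ccc(Cl)c(Cl)c1`: > 12500 nM

Read-out is a functional assay on K562 cells (Homo sapiens) for cytotoxicity, with a stated time of 72 h; on this read-out lower numbers stand for stronger inhibition and higher numbers for weaker inhibition. None of the three compounds gives a number in this assay. For compound 1 the entry > 20000 nM is a limit of the assay. For compound 2 the entry > 10000 nM is likewise a limit. For compound 3 the entry > 12500 nM is also a limit. Among the compounds with values here, compound 2 therefore stands at the limit of the limit of > 10000 nM in this assay, at which 1 of the 3 values shown sits, while the other two values sit at the limit of > 20000 nM in this assay, at which 1 of the 3 values shown sits, and (the limit of > 12500 nM in this assay, at which 1 of the 3 values shown sits); no step between any pair of them can be measured, and no order among them can be read from these entries.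

Compound 4 `C[C@H](NC(=O)c1cc(Cl)ccc1O)C(=O)Nc1cccc(Cl)c1` has not been measured in this assay. It differs from compound 2 in one place: methyl in place of hydrogen on a saturated chain carbon bound to an amide-type nitrogen and a carbonyl carbon, a methyl in place of hydrogen on a saturated chain carbon bound to an amide-type nitrogen and a carbonyl carbon. Within the data shown here, no measured pair shows what such a change does here, and compound 1 and compound 3, which already carry that methyl on their chains, give only limits. The step from compound 2 to compound 4 is expected to be none beyond the scatter, so that a step that the limit leaves unreadable from compound 2 to compound 4 is the estimated step. Compound 4 is estimated at 15000 nM, with a range from 5000 nM to 50000 nM, and most likely the assay will again report only a limit.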

Compound 4, half-maximal inhibitory concentration: > 10000 nM
Compound 4 ended at the assay's limit (the forecaster's own chance of this, stated with the estimate: 85%); the middle value lies beyond the limit too.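

Within the data shown here, compound 2 and compound 4 both stand as limits in this assay, so no step between them can be read, and the methyl in place of hydrogen on the chain has no readable effect. The compounds shown leave open what that methyl does, and whether any compound of this series gives an actual number in this assay.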